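The compounds below may be only part of what the source reports. "The series", "measured", "known", "first", "only" and "open" are said of these compounds alone.

Measured so far:
- compound 1 `COc1ccc(NC(=O)CCC(=O)OCCCCCCSc2ccc([N+](=O)[O-])c3nonc23)cc1` gives 130 nM in an assay on isolated protein for inhibition of glutathione S-transferase Mu 2 (Homo sapiens), with a stated time of 10 min; a higher number here means a weaker inhibitor, a lower number a stronger inhibitor
- compound 2 `COc1ccc(NC(=O)CCC(=O)OCCCCCCSc2ccc([N+](=O)[O-])c3nonc23)cc1OC` gives 360 nM
- compound 3 `CN(C)CCCNC(=O)CCC(=O)OCCCCCCSc1ccc([N+](=O)[O-])c2nonc12` gives 90 nM

Compound 3 holds the lowest number of the three, though one of its gaps is a 1.4-fold lower number from compound 1 to compound 3 (0.16 log units; within the scatter), within the scatter, and only the gap a 4.0-fold lower number from compound 2 to compound 3 (0.60 log units; beyond the scatter) exceeds it. Compound 4 `O=C(CCC(=O)N1CCOCC1)OCCCCCCSc1ccc([N+](=O)[O-])c2nonc12` carries morpholin-4-yl in place of (3-(dimethylamino)propyl)amino on a carbonyl carbon. Going by the values given here, no measured step reproduces this change; the steps bearing on the amide end are a 1.4-fold lower number from compound 1 to compound 3 (0.16 log units; within the scatter) and a 4.0-fold lower number from compound 2 to compound 3 (0.60 log units; beyond the scatter), both modest or within the scatter, so variation at this carbonyl has so far moved the number little. The expected step is therefore a 1.7-fold higher number from compound 3 to compound 4 (0.22 log units; within the scatter), at most a small rise and possibly none beyond the scatter. Compound 4 is estimated at 150 nM, within 60 nM to 400 nM.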

Compound 4, half-maximal inhibitory concentration: 170 nM
Compound 4: the middle estimate sits 1.1-fold (0.05 log units) below what was measured, within the range that was stated.
By their numbers in this assay, from the lowest: compounds 3, 1 and 4 (each within the scatter of the next); then compound 2.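

Replacing the secondary amide nitrogen with morpholin-4-yl, which brings a six-membered ring and removes the hydrogen-bond donor, still gives no change beyond the scatter in this assay: a 1.9-fold higher number from compound 3 to compound 4 (0.28 log units; within the scatter) and a 1.3-fold higher number from compound 1 to compound 4 (0.12 log units; within the scatter). Among these compounds, the amide hydrogen is therefore not required at this carbonyl carbon, and only the dimethoxyphenyl amide stands apart, with a 2.1-fold lower number from compound 2 to compound 4 (0.33 log units; beyond the scatter). No measurement shown accounts for these steps.

Still open, going by these compounds, is whether a piperidin-1-yl group or a carboxylic acid at this carbonyl carbon would stay in the same range.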